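From 1H-benzimidazol-2-yl to 2,5-dichlorophenyl on the sulfur-bound carbon

The compounds below may be only part of what the source reports. "The series", "measured", "known", "first", "only" and "open" are said of these compounds alone.

Compound 1, `Cc1cc(N2CC[C@@H](C)[C@@H](N(C)c3ncnc4[nH]ccc34)C2)n2nc(SCC3CC3)nc2n1`, in a toxicity assay on GES1 cells (Homo sapiens) for inhibition, read by MTT assay, with a stated time of 72 h (a lower number here means a stronger inhibitor, a higher number a weaker inhibitor), gives 27900 nM.
Compound 2, `Cc1cc(N2CC[C@@H](C)[C@@H](N(C)c3ncnc4[nH]ccc34)C2)n2nc(SCc3nc4ccccc4[nH]3)nc2n1`, in this assay gives 40200 nM.
Compound 3, `Cc1cc(N2CC[C@@H](C)[C@@H](N(C)c3ncnc4[nH]ccc34)C2)n2nc(SCc3ccccc3Br)nc2n1`, in this assay gives > 100000 nM, which is a limit of the assay and not a number.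

Of the two numbers available, compound 2 gives the higher one, with compound 1 nearest to it (a 1.4-fold higher number from compound 1 to compound 2 (0.16 log units; within the scatter)); as that gap lies within the scatter, the two cannot be ordered. Compound 4, `Cc1cc(N2CC[C@@H](C)[C@@H](N(C)c3ncnc4[nH]ccc34)C2)n2nc(SCc3cc(Cl)ccc3Cl)nc2n1`, is not yet measured. It differs from compound 2 in one place: 2,5-dichlorophenyl in place of 1H-benzimidazol-2-yl on a saturated chain carbon bound to a sulfur.

For the measured compounds named here, two measured steps bear on this change. Both an at least 3.5-fold higher number from compound 1 to compound 3 (0.55 log units; beyond the scatter) and an at least 2.4-fold higher number from compound 2 to compound 3 (0.39 log units; beyond the scatter) show that a halogen-bearing phenyl on the saturated chain carbon bound to a sulfur gave a weaker result, and compound 3 reached the limit (the limit of > 100000 nM in this assay, at which 1 of the 3 values shown sits). Since 2,5-dichlorophenyl resembles 2-bromophenyl more than 1H-benzimidazol-2-yl, a rise beyond the scatter is expected, a 2.5-fold higher number from compound 2 to compound 4 (0.40 log units; beyond the scatter), quite possibly again only a limit. The expected value for compound 4 is 100000 nM, within 40000 nM to 300000 nM.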

Compound 4, half-maximal inhibitory concentration: 87500 nM
The estimate for compound 4 lay 1.1-fold (0.06 log units) above the measured number; measured number inside the range.
By their numbers in this assay, from the lowest: compounds 1 and 2 (each within the scatter of the next); then compound 4. At a limit, above all of these: compound 3.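

In this assay, a halogen-bearing phenyl on a saturated chain carbon bound to a sulfur now has a measured size of change and not only a limit: replacing 1H-benzimidazol-2-yl gives a 2.2-fold higher number from compound 2 to compound 4 (0.34 log units; beyond the scatter), and replacing cyclopropyl gives a 3.1-fold higher number from compound 1 to compound 4 (0.50 log units; beyond the scatter). Both steps point towards weaker inhibition of these cells, so two different starting groups lead the same way when 2,5-dichlorophenyl enters. Replacing 2-bromophenyl with 2,5-dichlorophenyl gives an at least 1.1-fold lower number from compound 3 to compound 4 (0.05 log units; that floor lies within the scatter), and this floor fixes no size of change. Compound 3 stands at a limit and not at a number: the limit of > 100000 nM in this assay, at which 1 of the 4 values shown sits.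

As far as these compounds go, it remains open how a phenyl ring carrying a single chlorine would compare with compound 4. Also open, from the compounds shown here alone, is what an amine, a carboxylic acid or a longer chain at this place would give in this assay.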